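Quaternary ammonium quinolone carboxamides against collagen promoter activity

The source may hold more compounds than are shown below. What is called first, only, known or untested is meant among the compounds shown, and "the series" means these compounds.

Measured compounds:
compound 1 `CN(C)c1ccc2c(=O)c(C(=O)Nc3cc(F)cc(F)c3)cn(-c3ccc(OCCCCCCC[N+]45CCN(CC4)CC5)cc3Cl)c2n1`: 80%
compound 2 `CN(C)c1ccc2c(=O)c(C(=O)Nc3cc(F)cc(F)c3)cn(-c3ccc(OCCCCCCC[N+]45CCN(CC4)CC5)cc3F)c2n1`: 42.4%
compound 3 `CC[N+]1(CCCCCCCOc2ccc(-n3cc(C(=O)Nc4cc(F)cc(F)c4)c(=O)c4ccc(N(C)C)nc43)c(Cl)c2)CCCC1`: "not active" (no number reported)

In an assay on LX2 cells for inhibition of COL1A1 promoter (Homo sapiens), read by a luciferase reporter, with a stated time of 24 h, tested at 50 uM (a lower number here means a weaker effect, a higher number a stronger effect of the compound at the concentration tested), compound 1 gives 80% and compound 2 gives 42.4%. The two differ by fluoro in place of chloro on an aromatic carbon, and the step of a number 37.6 percentage points lower from compound 1 to compound 2 (beyond the scatter). Compound 3 carries a different core, differing from compound 1 by a group of 7 heavy atoms (6 carbon, 1 nitrogen; one five-membered non-aromatic ring with 1 hetero atom) in place of a group of 8 heavy atoms (6 carbon, 2 nitrogen; 2 six-membered non-aromatic rings with 2 hetero atoms each), on a saturated chain carbon, seven bonds along the chain from an oxygen on an aromatic ring; in this assay compound 3 is reported only as "not active" (no number reported), with no number given. Compound 4 `CC[N+]1(CCCCCCCOc2ccc(-n3cc(C(=O)Nc4cc(F)cc(F)c4)c(=O)c4ccc(N(C)C)nc43)c(F)c2)CCCC1` is not yet measured. Going by the values given here, it differs from compound 3 by fluoro in place of chloro on an aromatic carbon, which is the same change at the same place as the one from compound 1 to compound 2. In this assay compound 4 is expected to give about 5%, estimated between 0% and 20%. That expectation rests on compound 3 being reported as "not active" (no number reported) and on the drop a number 37.6 percentage points lower from compound 1 to compound 2 (beyond the scatter), which points to a weak result for compound 4 as well.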

Compound 4, a percentage reported as inhibition, at one concentration (the size of the read-out at that concentration, not a potency): "not active" (no number reported)
For compound 4 the study gives words and no number; the estimate stays without a comparison.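

Going by these compounds alone, compound 3 and compound 4 are both reported in words only, so no step for fluoro in place of chloro can be read between them. The compounds shown leave open whether this change has any effect on the background of compound 3. No evidence bearing on these results is available.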